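The compounds below may be only part of what the source reports. "The series", "measured", "known", "first", "only" and "open" are said of these compounds alone.

Compound 1 `CCN(CC)S(=O)(=O)c1ccc(S(=O)(=O)N2CCC[C@@H](C(=O)N(C)C(C)C)C2)cc1` stands at the highest of the two numbers in a functional assay on MIA PaCa-2 cells (Homo sapiens) for inhibition, read by MTT assay, with a stated time of 3 days (a higher number here means a weaker inhibitor, a lower number a stronger inhibitor), with 1400 nM. Compound 2 `CCOC(=O)[C@@H]1CCCN(S(=O)(=O)c2ccc(S(=O)(=O)N3CCCCC3)cc2)C1` gives 1000 nM in this assay, and the two values sit within the scatter of each other, so no order between them can be claimed. Compound 3 `CCN(CC)S(=O)(=O)c1ccc(S(=O)(=O)N2CCC[C@@H](C(=O)N3CCN(c4nc(C)no4)CC3)C2)cc1` has not yet been measured; it differs from compound 1 by 4-(3-methyl-1,2,4-oxadiazol-5-yl)piperazin-1-yl in place of isopropyl(methyl)amino on a carbonyl carbon. For the measured compounds named here, no step between measured compounds covers this change, so the expectation for this assay rests on compound 1 alone. The expected step is a 1.3-fold lower number from compound 1 to compound 3 (0.10 log units; within the scatter), with no direction expected beyond the scatter. Compound 3 is estimated at 1100 nM, within a range from 250 nM to 5000 nM.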

Compound 3, half-maximal inhibitory concentration: 200 nM
Beside the measured number, compound 3's estimate is 5.5-fold (0.74 log units) above it, outside the stated range (below it).
By their numbers in this assay, from the lowest: compound 3; then compounds 2 and 1 (each within the scatter of the next).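

In this assay there is a 7.0-fold lower number from compound 1 to compound 3 (0.85 log units; beyond the scatter) when 4-(3-methyl-1,2,4-oxadiazol-5-yl)piperazin-1-yl replaces isopropyl(methyl)amino on a carbonyl carbon. This position therefore accepts a larger group with two rings, and the change moves the number beyond the scatter, which the two earlier values did not show. Nothing available explains this gain.

From the compounds shown here alone, it remains open whether the gain needs the five-membered aromatic ring, the six-membered non-aromatic ring or both. A simple morpholin-4-yl on the same carbonyl carbon would help separate these.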